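The source may hold more compounds than are shown below. What is called first, only, known or untested is meant among the compounds shown, and "the series" means these compounds.

Among the compounds with values here, compound 2 `N#Cc1ccc(C(=O)NNC(=O)c2ccc(S(N)(=O)=O)cc2)cc1` stands highest of the two numbers so far: in an assay on cells for inhibition of Amine oxidase [flavin-containing] B (Homo sapiens), read by fluorescence and spectrophotometry, using microsomes, with a stated time of 20 min (a higher number here means a weaker inhibitor, a lower number a stronger inhibitor), compound 2 gives 1170 nM. Compound 1 `NS(=O)(=O)c1ccc(-c2nnc(-c3ccc(Cl)c(Cl)c3)o2)cc1`, built on a different core, sits far lower; in this assay compound 1 gives 2.7 nM. Compound 3 `NS(=O)(=O)c1ccc(C(=O)NNC(=O)c2ccc(Cl)c(Cl)c2)cc1` keeps the core of compound 2 and differs from it in one place (3,4-dichlorophenyl in place of 4-cyanophenyl on a carbonyl carbon). Within the data shown here, no step between measured compounds that differ in one place is available, so the size of the move rests only on the distance between compound 1 and compound 2, where the core also differs. A move of moderate size toward a lower number is expected, a 3.9-fold lower number from compound 2 to compound 3 (0.59 log units; beyond the scatter). Compound 3 is estimated at 300 nM, within a range of 60 nM to 1500 nM.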

Compound 3, half-maximal inhibitory concentration: 10100 nM
The estimate for compound 3 lay 34-fold (1.53 log units) below the measured number; measured number outside the range, above it.
By their numbers in this assay, from the lowest: compound 1; then compound 2; then compound 3.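

At the carbonyl carbon of this core, the aryl group matters: in this assay, 3,4-dichlorophenyl in place of 4-cyanophenyl gives an 8.6-fold higher number from compound 2 to compound 3 (0.94 log units; beyond the scatter) on the shared core. This single change moves the number upward, so this position is not indifferent to the exchange, and 4-cyanophenyl is the better of the two groups here. Nothing available accounts for the direction of this step.

On these data alone, with only these two groups read at this place, the trend remains open. An unsubstituted phenyl, a 4-methoxyphenyl or a pyridine ring could show whether the nitrile itself or the loss of the two chlorine atoms carries the step.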